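From carboxy to hydroxymethyl: notes on compound 3

A few compounds are considered here, and "the series" means these few. Any claim that something is new, unique, unknown or untested is made for them only; others in the source may bear on it.

Within the data shown here, in a functional assay on HCT-116 cells (Homo sapiens) for cytotoxicity, read by MTT assay, with a stated time of 3 days (a lower number here means a stronger inhibitor, a higher number a weaker inhibitor), compound 2 `CC(C)(C)c1cc2c(N/N=C/c3ccc(C(=O)O)cc3)ncnc2s1` gives 9.99 ug/mL and stands highest of the two numbers so far. Compound 1 `CC(C)(C)c1cc2c(N/N=C/c3ccc4c(c3)CNCC4)ncnc2s1` gives 0.107 ug/mL and lies lower, beyond the scatter. Compound 3 `CC(C)(C)c1cc2c(N/N=C/c3ccc(CO)cc3)ncnc2s1` carries hydroxymethyl in place of carboxy on an aromatic carbon, para to a large group (hydroxymethyl in place of carboxy on an aromatic carbon). Among the measured compounds shown here, no measured step isolates this change, so the expectation is loose. Compound 2 at 9.99 ug/mL leaves much room downward. The estimated step of a 4.0-fold lower number from compound 2 to compound 3 (0.60 log units; beyond the scatter) goes to a lower number and is expected to lie modestly beyond the scatter. The estimate for compound 3 is 2.5 ug/mL (range 0.5 ug/mL to 10 ug/mL).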

Compound 3, half-maximal inhibitory concentration: 0.665 ug/mL
Compound 3: the middle estimate sits 3.8-fold (0.58 log units) above what was measured; measured number inside the range.
By their numbers in this assay, from the lowest: compound 1; then compound 3; then compound 2.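

In this assay, among these compounds, hydroxymethyl in place of carboxy gives a 15-fold lower number from compound 2 to compound 3 (1.18 log units; beyond the scatter) as the first step that can be read. With the shared core unchanged, this place on the aromatic ring, para to a large group, proves sensitive to the group it carries. Nothing available bears on the reason for this step. Still open, as far as these compounds go, is how an amine, a methyl ester or a longer chain ending in hydroxyl would read at this place, and whether the step carries over to other cell lines.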